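Chloro in place of fluoro on compound 3

A few compounds are considered here, and "the series" means these few. Any claim that something is new, unique, unknown or untested is made for them only; others in the source may bear on it.

In a functional assay on DU-145 cells (Homo sapiens) for cytotoxicity, read by trypan blue exclusion, with a stated time of 96 h (a lower number here means a stronger inhibitor, a higher number a weaker inhibitor), compound 1 (`COC(=O)CNc1cc(CS(=O)(=O)/C=C/c2c(OC)cc(OC)cc2OC)ccc1OC`) gives 100 nM, compound 2 (`COC(=O)CCNc1cc(CS(=O)(=O)/C=C/c2c(OC)cc(OC)cc2OC)ccc1OC`) gives 1500 nM, and compound 3 (`COC(=O)C(Nc1cc(CS(=O)(=O)/C=C/c2c(OC)cc(OC)cc2OC)ccc1OC)c1ccc(F)cc1`) gives 300 nM. Compound 3 therefore sits in the middle of the three numbers. Compound 4 (`COC(=O)C(Nc1cc(CS(=O)(=O)/C=C/c2c(OC)cc(OC)cc2OC)ccc1OC)c1ccc(Cl)cc1`) differs from compound 3 in one place: chloro in place of fluoro on an aromatic carbon. This is chloro in place of fluoro on an aromatic carbon, para to a large group.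

Going by the values given here, no measured pair exchanges these two groups, so the data offer no direct guide. The closest evidence is the modest 3.0-fold higher number from compound 1 to compound 3 (0.48 log units; beyond the scatter), which came from adding the whole 4-fluorophenyl. The larger 15-fold higher number from compound 1 to compound 2 (1.18 log units; beyond the scatter) and the modest 5.0-fold lower number from compound 2 to compound 3 (0.70 log units; beyond the scatter) both involve changes to the chain on the nitrogen, which stays the same here. Exchanging only the fluoro is a much smaller edit than adding that ring, so no shift beyond the scatter is expected, and the estimated change is a 1.1-fold lower number from compound 3 to compound 4 (0.03 log units; within the scatter). The estimated value for compound 4 is 280 nM, with an expected range from 110 nM to 700 nM.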

Compound 4, half-maximal inhibitory concentration: 400 nM
Compound 4: the middle estimate sits 1.4-fold (0.15 log units) below what was measured; measured number inside the range.
By their numbers in this assay, from the lowest: compound 1; then compounds 3 and 4 (each within the scatter of the next); then compound 2.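

Exchanging fluoro for chloro on this aromatic carbon gives a 1.3-fold higher number from compound 3 to compound 4 (0.12 log units; within the scatter) and so, for this pair, the two halogens cannot be told apart. The ring's earlier behaviour also holds with chloro: adding 4-chlorophenyl to the chain carbon gives a 4.0-fold higher number from compound 1 to compound 4 (0.60 log units; beyond the scatter) and replacing the 2-(methoxycarbonyl)ethyl group with (4-chlorophenyl)(methoxycarbonyl)methyl gives a 3.8-fold lower number from compound 2 to compound 4 (0.57 log units; beyond the scatter) so neither direction depends on fluoro alone. Nothing available here accounts for these results.

The compounds shown cover only two halogens at this position, so it remains open whether bromo would behave like them or whether a methoxy, an amine or a carboxylic acid would shift the number. On these data alone, it is also open whether the ring's cost relative to compound 1 would shrink with the group on another ring carbon.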